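Ring substituent exchange: from compound 2 toward compound 3

The compounds below may be only part of what the source reports. "The series", "measured", "known", "first", "only" and "open" are said of these compounds alone.

Compound 2 `Fc1cccc(-c2nc(Nc3ccc(Cl)cc3)c3cc(F)ccc3n2)c1` and compound 1 `COc1ccc(Nc2nc(-c3cccc(F)c3)nc3ccc(F)cc23)cc1` sit within the scatter of each other, so neither stands apart. In a functional assay on COLO 205 cells (Homo sapiens) for cytotoxicity, read by MTT assay, with a stated time of 48 h (a lower number here means a stronger inhibitor, a higher number a weaker inhibitor), compound 1 gives 46800 nM and compound 2 gives 32600 nM. Among the measured compounds shown here, the only measured step, a 1.4-fold lower number from compound 1 to compound 2 (0.16 log units; within the scatter), changes the same ring that is altered here. Compound 3 `Fc1cccc(-c2nc(Nc3cccc(Br)c3)c3cc(F)ccc3n2)c1` differs from compound 2 by 3-bromophenyl in place of 4-chlorophenyl on a nitrogen on an aromatic ring. Given that the one relevant step stayed within the scatter, no movement beyond the scatter is expected in this assay. Compound 3 is estimated at 30000 nM, within 12000 nM to 80000 nM. The expected step is a 1.1-fold lower number from compound 2 to compound 3 (0.04 log units; within the scatter).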

Compound 3, half-maximal inhibitory concentration: > 50000 nM
Compound 3 gave a limit, no number; the forecaster's own chance of this, stated with the estimate: 10%; at least 1.6-fold (0.22 log units) between middle value and limit.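

In this assay compound 3 gives a limit, not a number: > 50000 nM. The change reads as an at least 1.5-fold higher number from compound 2 to compound 3 (0.18 log units; that floor lies within the scatter), and against the methoxy analogue as an at least 1.0-fold higher number from compound 1 to compound 3 (0.02 log units; that floor lies within the scatter). Both floors lie within the scatter, so 3-bromophenyl on this nitrogen is not shown to differ from either earlier group, although this is the first compound here to reach the limit: the limit of > 50000 nM in this assay, at which 1 of the 3 values shown sits.

On these data alone, how far compound 3 lies past that limit remains open. Also open, as far as these compounds go, is whether an amine or a carboxylic acid on this phenyl ring would give a clearly lower number.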